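Replacing 4-fluorophenyl with furan-2-yl: expected cell tolerance

This account rests on a few compounds, and the source may have more. Where it says the series, first, only, none or still open, it means among the compounds named here.

Two related compounds have been tested in an ADME assay on MRC5 cells (Homo sapiens) for cytotoxicity, read by MTT assay, with a stated time of 72 h; a lower number here means that less compound is tolerated, a higher number that more compound is tolerated. Compound 1 (`OC[C@H]1O[C@@H](n2cc(F)c3c(-c4ccco4)ncnc32)[C@H](O)[C@@H]1O`) gives 29000 nM. Compound 2 (`OC[C@H]1O[C@@H](n2cc(Cl)c3c(-c4ccc(F)cc4)ncnc32)[C@H](O)[C@@H]1O`) gives > 50000 nM, which is a limit of the assay and not a number, so it stands at the limit of > 50000 nM in this assay, at which 1 of the 2 values shown sits. Compound 3 (`OC[C@H]1O[C@@H](n2cc(Cl)c3c(-c4ccco4)ncnc32)[C@H](O)[C@@H]1O`) is still unmeasured. It keeps the rest of compound 2 but has furan-2-yl in place of 4-fluorophenyl on an aromatic carbon. Among the measured compounds shown here, no measured pair shows this change directly. Compound 1 also carries furan-2-yl and gives 29000 nM, so a moderate move toward a lower number in this assay, probably beyond the usual scatter, is expected. The estimated step is an at least 2.5-fold lower number from compound 2 to compound 3 (0.39 log units; beyond the scatter). For compound 3 the expected value is 20000 nM, with an estimated range from 7000 nM to 50000 nM.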

Compound 3, half-maximal cytotoxic concentration: > 50000 nM
Compound 3 was reported as a limit (the forecaster's own chance of this, stated with the estimate: 20%); at least 2.5-fold (0.39 log units) between middle value and limit.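

In this assay compound 3 gives > 50000 nM, which is a limit and not a number. With chloro on the shared core, furan-2-yl therefore does not bring the number down into the measurable range, and compound 3 stays at the same limit as compound 2, so that change cannot be read in size: the limit of > 50000 nM in this assay, at which 2 of the 3 values shown sit. The change of fluoro to chloro with furan-2-yl kept gives an at least 1.7-fold higher number from compound 1 to compound 3 (0.23 log units; that floor lies within the scatter), so the data do not establish a real difference between these two halogens.

From the compounds shown here alone, how far compound 2 and compound 3 lie beyond the limit stays open, as does whether they differ at all. Also open, going by these compounds, is how the cells would tolerate an amine or a carboxylic acid in place of furan-2-yl on this aromatic carbon.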